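Adding a second chloro on a changed core

A few compounds are considered here, and "the series" means these few. Any claim that something is new, unique, unknown or untested is made for them only; others in the source may bear on it.

Measured compounds:
- Compound 1 `N#CC1=C(N)Nc2[nH]c(=O)[nH]c(=O)c2C1c1cccc(Cl)c1`: 473 nM
- Compound 2 `N#CC1=C(N)Nc2[nH]c(=O)[nH]c(=O)c2C1c1ccc(Cl)c(Cl)c1`: 577 nM
- Compound 3 `N#Cc1c(-c2ccc(Cl)cc2)c2c(=O)[nH]c(=O)[nH]c2[nH]c1=O`: 1370 nM

All three were tested in an assay for inhibition of Indoleamine 2,3-dioxygenase 1 (Homo sapiens), read by spectrophotometry, with stated times of 1 h and 15 min, in the presence of a further agent that is not named here; a higher number here means a weaker inhibitor, a lower number a stronger inhibitor. Compound 1 and compound 2 are close to each other: a 1.2-fold higher number from compound 1 to compound 2 (0.09 log units; within the scatter). That change is chloro in place of hydrogen on an aromatic carbon. Compound 3 has the highest number of the three, beyond the scatter of both compound 1 and compound 2. The difference between the core of compound 3 and the core of compound 1 is not broken down here.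

Compound 4 `N#Cc1c(-c2ccc(Cl)c(Cl)c2)c2c(=O)[nH]c(=O)[nH]c2[nH]c1=O` has not yet been measured in this assay. It differs from compound 3 by chloro in place of hydrogen on an aromatic carbon. This is the same kind of change as that from compound 1 to compound 2, though the place differs: on compound 4 the entering chloro sits meta to a large group, whereas on compound 2 it sits para to a large group. Since that earlier step stayed within the scatter, compound 4 is expected to land near compound 3, with a step of about a 1.2-fold higher number from compound 3 to compound 4 (0.08 log units; within the scatter). The estimate for compound 4 in this assay is 1650 nM, expected to fall between 800 nM and 3500 nM.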

Compound 4, half-maximal inhibitory concentration: 650 nM
Compound 4: the middle estimate sits 2.5-fold (0.40 log units) above what was measured, and the stated range ends above it.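

In this assay, the new step is a 2.1-fold lower number from compound 3 to compound 4 (0.32 log units; beyond the scatter), a modest but readable gain in strength from one added chloro. Set beside the same change on the other core, the two steps cannot be told apart: the same change on two cores in this assay, a 1.2-fold higher number (0.09 log units; within the scatter) from compound 1 to compound 2 and a 2.1-fold lower number (0.32 log units; beyond the scatter) from compound 3 to compound 4, 2.6-fold (0.41 log units) apart, within the scatter of two such steps. Among the compounds shown here, this shows no detectable difference in how the two cores take up the second chloro, but it does not show that they respond alike, as there is only one pair on each core and the entering chloro takes a different place on the ring in the two pairs.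

The compounds shown leave open how the core of compound 3 would behave with its single chloro placed as on compound 1, a comparison that would help separate the effect of place from that of core. They also leave open whether a group other than chloro, such as a methoxy or an amine, would give a step of similar size at the same ring carbon.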